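The source may report more compounds than this note shows. Statements on the series, on what has been measured and on what is new or still open speak of the compounds shown alone.

Measured so far in a functional assay on HOP-62 cells (Homo sapiens) for inhibition, read by sulforhodamine B assay; a lower number here means a stronger inhibitor of growth, a higher number a weaker inhibitor of growth:
- compound 1 `Cc1ccc2[nH]c(-c3ccc(-c4ccc(-c5ccc(N(C)C)cc5)cc4)cc3)nc2c1` at 4230 nM
- compound 2 `Cc1ccc2[nH]c(-c3ccc(-c4ccc(-c5ccccc5)cc4)cc3)nc2c1` at 39300 nM

Of these two, compound 2 holds the higher number, at 39300 nM in this assay, so it is the weaker inhibitor of growth. Compound 3 `Cc1ccc2[nH]c(-c3ccc(-c4ccc(-c5ccc(C(F)(F)F)cc5)cc4)cc3)nc2c1` departs from compound 2 by one change, (trifluoromethyl in place of hydrogen on an aromatic carbon), that is, trifluoromethyl in place of hydrogen on an aromatic carbon. Going by the values given here, only one measured step bears on this: a 9.3-fold higher number from compound 1 to compound 2 (0.97 log units; beyond the scatter), a modest step with hydrogen in place of dimethylamino on an aromatic carbon. Among the compounds with values here, that step gives a scale for such a change, yet no measured compound carries trifluoromethyl, so the direction remains uncertain. Within the data shown here, a smaller step towards a lower number is expected, with compound 1 at 4230 nM as the only guide. The estimated move is a 2.0-fold lower number from compound 2 to compound 3 (0.29 log units; within the scatter) in this reading. Compound 3 is therefore expected at 20000 nM (estimated range 6000 nM to 70000 nM).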

Compound 3, concentration for 50% growth inhibition: 24200 nM
Beside the measured number, compound 3's estimate is 1.2-fold (0.08 log units) below it, within the range that was stated.
By their numbers in this assay, from the lowest: compound 1; then compounds 3 and 2 (each within the scatter of the next).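

In this assay, trifluoromethyl on this aromatic carbon, para to a large group, gives a 1.6-fold lower number from compound 2 to compound 3 (0.21 log units; within the scatter) so at this position the group cannot be told apart from hydrogen. Trifluoromethyl in place of dimethylamino gives a 5.7-fold higher number from compound 1 to compound 3 (0.76 log units; beyond the scatter) and so, among these three compounds, only the dimethylamino group of compound 1 stands apart from the other two substituents at this position. No measurement shown accounts for this difference between the groups.

The compounds shown leave open whether the lower number belongs to dimethylamino alone or also appears with other groups at this place, such as a primary amine, a methoxy group or a morpholine ring. They also leave open whether a longer chain on the nitrogen would keep the number of compound 1.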